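A few compounds are considered here, and "the series" means these few. Any claim that something is new, unique, unknown or untested is made for them only; others in the source may bear on it.

Compound 1 `COc1cc(-n2cnc3ccc(-c4ccccc4Cl)cc32)cc(OC)c1OC` carries a 2-chlorophenyl group on its shared core. In a functional assay on SGC-7901 cells (Homo sapiens) for antiproliferative activity, read by MTT assay, with a stated time of 72 h (on this read-out lower numbers stand for stronger inhibition and higher numbers for weaker inhibition), compound 1 gives > 10000 nM, which is a limit of the assay rather than a measured number. Two measured relatives share the same core: compound 2 `COc1cc(-n2cnc3ccc(-c4cccc(O)c4)cc32)cc(OC)c1OC` gives 53 nM, and compound 3 `COc1cc(-n2cnc3ccc(-c4cccc(C)c4)cc32)cc(OC)c1OC` gives 1240 nM. Moving to a 3-hydroxyphenyl gave an at least 180-fold lower number from compound 1 to compound 2 (2.27 log units; beyond the scatter), moving to a 3-methylphenyl gave an at least 8.0-fold lower number from compound 1 to compound 3 (0.90 log units; beyond the scatter), and methyl in place of hydroxy gave a 23-fold higher number from compound 2 to compound 3 (1.37 log units; beyond the scatter). Compound 4 `COc1cc(-n2cnc3ccc(-c4cccc(C)c4C)cc32)cc(OC)c1OC` is not yet measured; it differs from compound 1 by 2,3-dimethylphenyl in place of 2-chlorophenyl on an aromatic carbon. Because the 3-methylphenyl gave an at least 8.0-fold lower number from compound 1 to compound 3 (0.90 log units; beyond the scatter), some move downward is expected, but the 2,3-dimethylphenyl stays closer to the 2-chlorophenyl of compound 1 than compound 3 does, so the number is expected to remain high. Compound 4 is therefore expected to give 5000 nM, between 1000 nM and 20000 nM, which means an expected at least 2.0-fold lower number from compound 1 to compound 4 (0.30 log units; that floor lies within the scatter).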

Compound 4, half-maximal inhibitory concentration: 3040 nM
Compound 4: the middle estimate sits 1.6-fold (0.22 log units) above what was measured, and the stated range covers the measured number.
By their numbers in this assay, from the lowest: compound 2; then compound 3; then compound 4. At a limit, above all of these: compound 1.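

In this assay, adding a methyl group to the 3-methylphenyl of compound 3 to give the 2,3-dimethylphenyl produces a 2.5-fold higher number from compound 3 to compound 4 (0.39 log units; beyond the scatter), so this extra methyl costs some activity without abolishing it. Against the 3-hydroxyphenyl the loss is far larger, with a 57-fold higher number from compound 2 to compound 4 (1.76 log units; beyond the scatter). Replacing the 2-chlorophenyl gives an at least 3.2-fold lower number from compound 1 to compound 4 (0.51 log units; beyond the scatter), and this size is only a floor, since the value of compound 1 is a limit: the limit of > 10000 nM in this assay, at which 1 of the 4 values shown sits.

As far as these compounds go, it remains open whether a 2-methylphenyl alone would behave like the 2-chlorophenyl or the 2,3-dimethylphenyl. From the compounds shown here alone, how a 3-aminophenyl or 3-methoxyphenyl would compare with the 3-hydroxyphenyl also remains open.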